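The source may hold more compounds than are shown below. What is called first, only, known or untested is meant among the compounds shown, and "the series" means these compounds.

In a functional assay on MCF7 cells (Homo sapiens) for cytotoxicity, read by MTT assay, with a stated time of 72 h (a lower number here means a stronger inhibitor, a higher number a weaker inhibitor), three compounds sharing one core have been measured. Compound 1 (`COc1ccc(/C=C2\CCC/C(=C\c3ccc(Cl)cc3)C2=O)cc1OC`) gives 6300 nM. Compound 2 (`COc1ccc(/C=C2\CCC/C(=C\c3cccc(O)c3)C2=O)cc1OC`) gives 2900 nM. Compound 3 (`COc1ccc(/C=C2\CCC/C(=C\c3cccc(Cl)c3Cl)C2=O)cc1OC`) gives 14300 nM, the highest of the three numbers. Compound 4 (`COc1ccc(/C=C2\CCC/C(=C\c3cc(Cl)cc(Cl)c3)C2=O)cc1OC`) has not yet been measured and differs from compound 3 at a single place: 3,5-dichlorophenyl in place of 2,3-dichlorophenyl on a double-bonded chain carbon bound to a double-bonded ring carbon. There, 3,5-dichlorophenyl stands in place of 2,3-dichlorophenyl on a double-bonded chain carbon bound to a double-bonded ring carbon.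

All three measured steps were made at this same place, and all are modest: a 2.2-fold lower number from compound 1 to compound 2 (0.34 log units; beyond the scatter), a 2.3-fold higher number from compound 1 to compound 3 (0.36 log units; beyond the scatter) and a 4.9-fold higher number from compound 2 to compound 3 (0.69 log units; beyond the scatter). Among the compounds with values here, none of the measured compounds carries 3,5-dichlorophenyl, so the evidence is indirect. Compound 3 holds the highest number, and the modest 2.3-fold higher number from compound 1 to compound 3 (0.36 log units; beyond the scatter) is the closest guide, so a modest move toward a lower number is expected. The expected change in this assay is a 2.0-fold lower number from compound 3 to compound 4 (0.31 log units; beyond the scatter). For compound 4 the estimated value is 7000 nM, with an expected range from 3000 nM to 15000 nM.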

Compound 4, half-maximal inhibitory concentration: 3800 nM
Beside the measured number, compound 4's estimate is 1.8-fold (0.27 log units) above it; measured number inside the range.
By their numbers in this assay, from the lowest: compounds 2, 4 and 1 (each within the scatter of the next, the first and the last beyond it); then compound 3.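

In this assay, the atoms stay the same and only their joining changes, yet 3,5-dichlorophenyl in place of 2,3-dichlorophenyl gives a 3.8-fold lower number from compound 3 to compound 4 (0.58 log units; beyond the scatter) (a step beyond the scatter), so at this position the arrangement of the two chlorines matters and not merely their presence. Two chlorines do not by themselves set a compound apart, since a 1.3-fold higher number from compound 2 to compound 4 (0.12 log units; within the scatter) and a 1.7-fold lower number from compound 1 to compound 4 (0.22 log units; within the scatter) both stay within the scatter, and among the compounds shown only compound 3 stands clear of the others. Nothing at hand accounts for the difference between these two dichlorophenyl groups.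

The compounds shown leave open how 3-chlorophenyl or 2-chlorophenyl, each with a single chlorine, would compare with the two dichlorophenyl groups. They also leave open whether an amine or a carboxylic acid on the same ring would move the number in either direction.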